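Swapping Cyclopentyloxy for Chloro on a Shared Core

The compounds below may be only part of what the source reports. "The series", "measured", "known", "first", "only" and "open" are said of these compounds alone.

Of the compounds shown here, three with a shared core have been measured in a toxicity assay on A549 cells (Homo sapiens) for cytotoxicity, read by luminescence and CellTiter-Glo, with a stated time of 48 h; a higher number here means that more compound is tolerated, a lower number that less compound is tolerated. Compound 1 `CCOC(=O)CCCOc1ccc(-c2nc3ncccn3c2NC2CCCCC2)cc1` gives only a limit of the assay, > 100000 nM. Compound 2 `COCCCCOc1ccc(-c2nc3ncccn3c2NC2CCCCC2)cc1` gives 100000 nM, and compound 3 `c1cnc2nc(-c3ccc(OC4CCCC4)cc3)c(NC3CCCCC3)n2c1` gives 39000 nM, the lowest of the two numbers, its nearest neighbour being a 2.6-fold lower number from compound 2 to compound 3 (0.41 log units; beyond the scatter). Compound 4 `Clc1ccc(-c2nc3ncccn3c2NC2CCCCC2)cc1` differs from compound 3 by chloro in place of cyclopentyloxy on an aromatic carbon. All measured steps alter the group on the aromatic oxygen: an at least 2.5-fold lower number from compound 1 to compound 3 (0.40 log units; beyond the scatter) and a 2.6-fold lower number from compound 2 to compound 3 (0.41 log units; beyond the scatter) each lowered the number when cyclopentyl replaced a chain, while a number no higher from compound 1 to compound 2 (the limit leaves the size open) remained open in size. Going by the values given here, no measured step removes the oxygen itself. The expected step is therefore small, a 1.3-fold lower number from compound 3 to compound 4 (0.11 log units; within the scatter). Compound 4 is estimated at 30000 nM, between 10000 nM and 100000 nM.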

Compound 4, half-maximal cytotoxic concentration: > 100000 nM
Compound 4: only a limit was reported; the forecaster's own chance of this, stated with the estimate: 20%; middle value at least 3.3-fold (0.52 log units) away from the limit.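

Measured in this assay, chloro on the aromatic carbon gives an at least 2.5-fold higher number from compound 3 to compound 4 (0.40 log units; beyond the scatter), so this position also responds when the oxygen itself leaves, and compound 3 remains the least tolerated of the four. Against the 4-methoxybutoxy chain, the same change gives a number no lower from compound 2 to compound 4 (the limit leaves the size open), and the step from compound 1 cannot be read. From the compounds shown here alone, the size of these steps stays open because compound 4 gives only a limit: the limit of > 100000 nM in this assay, at which 2 of the 4 values shown sit.

Going by these compounds, whether the oxygen or the cyclopentyl ring matters more remains open. A methoxy group or an amine at this carbon could separate the two.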